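The source may hold more compounds than are shown below. What is called first, only, known or untested is meant among the compounds shown, and "the series" means these compounds.

Three related compounds have been read in an ADME assay (liver) for metabolic stability, with Liver microsome (Rattus norvegicus) as the target, using microsomes; on this read-out lower numbers stand for slow clearance and higher numbers for fast clearance. Compound 1 `Fc1cc2cc(-c3nnc(NCc4ccccc4)o3)ccc2cn1` gives 56 mL.min-1.g-1, and compound 3 `c1ccc(CNc2nnc(-c3c[nH]c4ncccc34)o2)cc1` gives 40 mL.min-1.g-1. These two numbers lie within the usual scatter of each other, so they cannot be ranked. For compound 2 `O=C1Cc2cc(-c3nnc(NCc4ccccc4)o3)ccc2N1`, this assay reports only a limit, < 14 mL.min-1.g-1. Compound 3 is therefore one of the two compounds with a true number, and it sits level with compound 1 within that scatter.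

Compound 4 `Fc1ccc(CNc2nnc(-c3c[nH]c4ncccc34)o2)cc1` changes compound 3 in a single place: fluoro in place of hydrogen on an aromatic carbon. In words, phenyl turns into 4-fluorophenyl. Going by the values given here, no measured pair here differs in only one place, so the set offers no direct precedent for this step. Only a small change in this assay is expected, none beyond the scatter, and no firm direction can be given. As measured, compound 3 gives 40 mL.min-1.g-1. The expected step is a 1.1-fold lower number from compound 3 to compound 4 (0.02 log units; within the scatter). The estimate for compound 4 is 38 mL.min-1.g-1, with an expected range from 20 mL.min-1.g-1 to 75 mL.min-1.g-1.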

Compound 4, intrinsic clearance in microsomes: 58 mL.min-1.g-1
The estimate for compound 4 lay 1.5-fold (0.18 log units) below the measured number, within the range that was stated.
By their numbers in this assay, from the lowest: compounds 3, 1 and 4 (each within the scatter of the next). At a limit, below all of these: compound 2.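

In this assay, going by these compounds alone, the change from phenyl to 4-fluorophenyl gives the only step in the set between compounds that differ in one place: a 1.5-fold higher number from compound 3 to compound 4 (0.16 log units; within the scatter). At this position, para to a large group, fluoro in place of hydrogen therefore leaves compound 4 level with compound 3, with no shift that can be told from the scatter. No information given here bears on a cause for this step, and a single step within the scatter shows no trend.

The compounds shown leave open whether a different group at this position, such as chloro, methoxy or an amine, would give a step beyond the scatter. On these data alone, it also remains open whether the same change from phenyl to 4-fluorophenyl would read alike on the core of compound 1 or the core of compound 2.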